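The compounds below may be only part of what the source reports. "The series", "measured", "known", "first", "only" and "open" are said of these compounds alone.

Measured so far:
- compound 1, `CC(C)Cc1nn(C)c(=O)c2c(SCCCO)n(Cc3cnc(NCCCCCNC(=O)[C@@H](N)CCC(N)=O)c4ccccc34)cc12`: 0.16 nM
- compound 2, `CC(C)Cc1nn(C)c(=O)c2c(SCCCO)n(Cc3cnc(NCCCCCN)c4ccccc34)cc12`: 0.8 nM

Going by the values given here, in an assay on Raji cells for inhibition of Monocarboxylate transporter 1 (Homo sapiens), read by MTT assay, with a stated time of 96 h (a lower number here means that less compound is needed, a higher number that more compound is needed for the effect), compound 2 gives 0.8 nM, the higher of the two numbers: its only neighbour is compound 1, and a 5.0-fold higher number from compound 1 to compound 2 (0.70 log units; beyond the scatter) shows that removing the amide-bearing end of the chain already costs something. Compound 3, `CC(C)Cc1nn(C)c(=O)c2c(SCCCO)n(Cc3cnc(Cl)c4ccccc34)cc12`, goes further in the same direction: chloro in place of (5-aminopentyl)amino on an aromatic carbon. Among the compounds with values here, no measured pair shows what happens when the whole chain is taken away and only a chlorine remains, so the single step from compound 1 to compound 2 is the only guide, and it points to a rise in the number. Since a much larger piece is removed here than in that step, a further rise beyond the scatter is expected, but its size is uncertain. The expected step is a 5.0-fold higher number from compound 2 to compound 3 (0.70 log units; beyond the scatter), giving for compound 3 an estimate of 4 nM, within 0.8 nM to 30 nM.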

Compound 3, half-maximal effective concentration: 55 nM
The estimate for compound 3 lay 14-fold (1.14 log units) below the measured number; measured number above the stated range.
By their numbers in this assay, from the lowest: compound 1; then compound 2; then compound 3.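

In this assay, a 69-fold higher number from compound 2 to compound 3 (1.84 log units; beyond the scatter) when chloro replaces the (5-aminopentyl)amino group, a much larger step than a 5.0-fold higher number from compound 1 to compound 2 (0.70 log units; beyond the scatter), where only the group on the end of the chain was lost. This aromatic carbon, next to the ring nitrogen, is therefore sensitive to what it carries, and removing the whole chain costs far more than trimming its end. Nothing available explains why the number rises so steeply.

This single swap removes the chain and introduces chlorine at once, so the compounds shown cannot separate the two changes. A plain hydrogen or a simple amine on this carbon would help to separate them, and a shorter or longer chain would show how much of the chain is needed to keep the number low.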